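The source may report more compounds than this note shows. Statements on the series, on what has been measured and on what is new or still open speak of the compounds shown alone.

Compound 1, `COc1cc[nH]c1/C=C1\C(=O)Nc2ccc([N+](=O)[O-])cc21`, gives 692 nM in a functional assay on RKO cells (Homo sapiens) for antiproliferative activity, read by MTT assay, with a stated time of 5 days (on this read-out lower numbers stand for stronger inhibition and higher numbers for weaker inhibition), and stands highest of the two numbers in hand; compound 2, `COc1cc[nH]c1/C=C1\C(=O)Nc2ccc([N+](=O)[O-])c(N3CC[C@@H](O)C3)c21`, gives 32 nM. Compound 3 is `COc1cc[nH]c1/C=C1\C(=O)Nc2ccc(F)cc21`; it differs from compound 1 by fluoro in place of nitro on an aromatic carbon. Among the measured compounds shown here, the only measured step, a 22-fold lower number from compound 1 to compound 2 (1.33 log units; beyond the scatter), concerns a different change and does not bear on this one, so nothing measured speaks to the swap directly. Compound 3 is therefore expected, with wide uncertainty, to give a somewhat higher number than compound 1, a step of a 2.2-fold higher number from compound 1 to compound 3 (0.34 log units; beyond the scatter), estimated at 1500 nM within a range of 400 nM to 6000 nM.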

Compound 3, half-maximal inhibitory concentration: 11900 nM
Beside the measured number, compound 3's estimate is 7.9-fold (0.90 log units) below it; measured number above the stated range.
By their numbers in this assay, from the lowest: compound 2; then compound 1; then compound 3.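

In this assay, fluoro in place of nitro on this aromatic carbon gives a 17-fold higher number from compound 1 to compound 3 (1.24 log units; beyond the scatter) on an otherwise unchanged core. The group at this position therefore matters in its own right, and of the two groups shown, nitro goes with the lower number. Nothing at hand gives a reason for this step. Going by these compounds, whether a nitrile, an amine or a carboxylic acid on this carbon would stand nearer compound 1 or compound 3 stays open. Also open, on these data alone, is whether the 3-hydroxypyrrolidin-1-yl group would lower the number with fluoro in place of nitro.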